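From 2-bromophenyl to 4-fluorophenyl: working notes on the series

This account rests on a few compounds, and the source may have more. Where it says the series, first, only, none or still open, it means among the compounds named here.

- compound 1 `Cc1ccc(OCC(=O)NNC(=O)c2cc3ccccc3oc2=O)c(C(=O)c2ccccc2Br)c1` gives 10600 nM
- compound 2 `Cc1ccc(OCC(=O)NNC(=O)c2cc3ccccc3oc2=O)c(C(=O)c2ccccc2)c1` gives 87000 nM
- compound 3 `Cc1ccc(OCC(=O)NNC(=O)c2cc3ccccc3oc2=O)c(C(=O)c2cccc(Br)c2)c1` gives 69800 nM

In a functional assay on DLA cells (Mus musculus) for cytotoxicity, read by LDH release, with a stated time of 48 h (a lower number here means a stronger inhibitor, a higher number a weaker inhibitor), compound 1 stands lowest of the three at 10600 nM and lies clear of both others by more than the scatter. Compound 4 `Cc1ccc(OCC(=O)NNC(=O)c2cc3ccccc3oc2=O)c(C(=O)c2ccc(F)cc2)c1` has not yet been measured. It carries 4-fluorophenyl in place of 2-bromophenyl on a carbonyl carbon.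

Two measured steps leave 2-bromophenyl behind, and both raise the number. Hydrogen in place of bromo gives an 8.2-fold higher number from compound 1 to compound 2 (0.91 log units; beyond the scatter) and 3-bromophenyl in place of 2-bromophenyl gives a 6.6-fold higher number from compound 1 to compound 3 (0.82 log units; beyond the scatter) in the same direction. The remaining step of a 1.2-fold lower number from compound 2 to compound 3 (0.10 log units; within the scatter) lies within the scatter, so neither of those two ranks ahead of the other. Among the compounds with values here, no measured compound carries 4-fluorophenyl, and the data give no separate reading for that group. Compound 4 also lacks 2-bromophenyl, so a step close in size to a 6.6-fold higher number from compound 1 to compound 3 (0.82 log units; beyond the scatter) is expected. The expected change is a 6.1-fold higher number from compound 1 to compound 4 (0.79 log units; beyond the scatter) toward a weaker inhibitor. The estimate for compound 4 is 65000 nM (expected range 25000 nM to 150000 nM).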

Compound 4, half-maximal inhibitory concentration: 45700 nM
Estimate against measurement, compound 4: 1.4-fold (0.15 log units) above, and the stated range covers the measured number.
By their numbers in this assay, from the lowest: compound 1; then compounds 4, 3 and 2 (each within the scatter of the next).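

In this assay a third replacement of 2-bromophenyl on the carbonyl carbon, now by 4-fluorophenyl, gives a 4.3-fold higher number from compound 1 to compound 4 (0.63 log units; beyond the scatter) and so points the same way as the two earlier replacements, leaving compound 1 clear of every other compound in the series. The new group does not stand apart from the others, since a 1.5-fold lower number from compound 3 to compound 4 (0.18 log units; within the scatter) and a 1.9-fold lower number from compound 2 to compound 4 (0.28 log units; within the scatter) are both printed as within the scatter, so compound 2, compound 3 and compound 4 cannot be told apart and fluoro in place of hydrogen gives no readable effect here. Nothing at hand explains why compound 1 alone stands apart from the rest.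

The compounds shown leave open whether the low number of compound 1 belongs to bromo itself or would also come with 2-chlorophenyl, 2-fluorophenyl or 2-methoxyphenyl on the same carbonyl carbon. They also leave open whether a ring carrying a different kind of group, such as an amine or a carboxylic acid, would stay level with compound 2, compound 3 and compound 4 or move away from them.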